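The compounds below may be only part of what the source reports. "The series", "measured", "known", "first", "only" and "open" are said of these compounds alone.

Working notes on the series.

Within the data shown here, compound 1 `COc1ccc(Cn2nc(Nc3cc(C)[nH]n3)c3ccccc3c2=O)cc1` is the only member with a number: in a functional assay on COLO 205 cells (Homo sapiens) for cytotoxicity (on this read-out higher numbers stand for weaker inhibition and lower numbers for stronger inhibition), compound 1 gives 4200 nM. Compound 2 `CC(=O)Nc1ccc(Cn2nc(Nc3cc[nH]n3)c3ccccc3c2=O)cc1` carries the acetamido group on the benzyl ring in place of the methoxy group of compound 1 and has no hydrogen-bond-accepting methyl on the pyrazole; in this assay compound 2 gives "not determined" (no result reported), so there is no single number to place it against compound 1, and nothing can be said about where compound 2 stands.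

Compound 3 `CC(=O)Nc1ccc(Cn2nc(Nc3cc(C)[nH]n3)c3ccccc3c2=O)cc1` is the next member. The change from compound 2 to compound 3 is methyl in place of hydrogen on an aromatic carbon. Among the measured compounds shown here, no measured pair shows the size of this step, so its direction in this assay cannot be read from the series; a step of this kind is expected to stay within the usual scatter, or at most to move potency slightly in either direction.

Compound 3 shares the methyl-bearing pyrazole with compound 1, which gives 4200 nM, and this is the only anchor. On that basis compound 3 is estimated at 3000 nM in this assay, with an expected range from 800 nM to 12000 nM.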

Compound 3, half-maximal inhibitory concentration: > 30000 nM
Compound 3 was reported as a limit; the forecaster's own chance of this, stated with the estimate: 10%; middle value at least 10-fold (1.00 log units) from the limit.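

Among these compounds, the first measured pair holds the methyl-bearing pyrazole and the core fixed and changes only the group on the benzyl ring: in this assay, acetamido in place of methoxy on an aromatic carbon gives an at least 7.1-fold higher number from compound 1 to compound 3 (0.85 log units; beyond the scatter), so the read-out is sensitive to the group at this place, which no earlier comparison could show. Compound 3 is reported as a limit, > 30000 nM. The step therefore gives only a minimum size, and how far the acetamido compound lies from the methoxy compound stays undefined: the limit of > 30000 nM in this assay, at which 1 of the 3 values shown sits.

As far as these compounds go, the step from hydrogen to methyl on the pyrazole cannot be read, since compound 2 has no number, and the contribution of the 5-methyl-1H-pyrazol-3-yl group to the read-out remains unknown. Also open, from the compounds shown here alone, is whether a simple amine or a carboxylic acid at the same place on the benzyl ring would give a value closer to that of compound 1 or to the limit of compound 3.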